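A few compounds are considered here, and "the series" means these few. Any claim that something is new, unique, unknown or untested is made for them only; others in the source may bear on it.

Four compounds that share one core are compared in an assay on isolated protein for inhibition of Rho-associated protein kinase 2 (Homo sapiens), read by scintillation counting, radiometric assay and 33P incorporation, with a stated time of 40 min, in the presence of a further agent that is not named here; a higher number here means a weaker inhibitor, a lower number a stronger inhibitor. Compound 1 `Cc1cc(NC(=O)COc2ccc3c(=O)ccoc3c2)cc(NC(=O)c2ccc(N(C)C)cc2)c1` gives > 10000 nM in this assay, which is a limit of the assay and not a number. Compound 2 `CN(C)c1ccc(C(=O)Nc2cc(NC(=O)COc3ccc4c(=O)ccoc4c3)cc(C(F)(F)F)c2)cc1` gives > 10000 nM in this assay, again a limit. Compound 2 differs from compound 1 by trifluoromethyl in place of methyl on an aromatic carbon, and the step that the two limits leave unreadable from compound 1 to compound 2 stays unreadable because of the limit of > 10000 nM in this assay, at which 2 of the 3 values shown sit.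

Compound 3 `Cc1cc(NC(=O)COc2ccc3c(=O)ccoc3c2)ccc1NC(=O)c1ccc(N(C)C)cc1` has the same atoms as compound 1 joined differently; the difference between the two cores is not broken down here. In this assay, for the measured compounds named here, compound 3 gives 4210 nM, the only plain number among the three measured compounds.

Compound 4 `CN(C)c1ccc(C(=O)Nc2ccc(NC(=O)COc3ccc4c(=O)ccoc4c3)cc2C(F)(F)F)cc1` has not yet been measured. It differs from compound 3 by trifluoromethyl in place of methyl on an aromatic carbon. This is the same kind of change as that from compound 1 to compound 2, but not the same: in compound 2 the entering group sits meta to two large groups, whereas in compound 4 it sits ortho to a large group and meta to a large group.

The step from compound 3 to compound 4 in this assay is expected to be a 1.9-fold higher number from compound 3 to compound 4 (0.28 log units; within the scatter), an expectation that rests on compound 3 giving 4210 nM and on the earlier step that the two limits leave unreadable from compound 1 to compound 2 offering no readable direction. Compound 4 is therefore estimated to give about 8000 nM, with an expected range from 2500 nM to 25000 nM, in this assay.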

Compound 4, half-maximal inhibitory concentration: 7100 nM
The estimate for compound 4 lay 1.1-fold (0.05 log units) above the measured number; the measured number falls inside the stated range.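

In this assay, putting trifluoromethyl in place of methyl on the core of compound 3 gives a 1.7-fold higher number from compound 3 to compound 4 (0.23 log units; within the scatter), so on this core the swap produces no change that can be told apart from the ordinary spread of repeated measurements. The same swap on the other core, from compound 1 to compound 2, cannot be read, because both compounds rest on a limit of the assay and not on a number: the limit of > 10000 nM in this assay, at which 2 of the 4 values shown sit. This leaves a single readable pair, which shows that the swap is tolerated on one core but does not show whether the two cores respond alike, so nothing here establishes that the result carries from one core to the other.

The compounds shown leave open whether a different group at this place on the ring, such as a chlorine atom, a nitrile, a methoxy group or an amine, would shift the number beyond the scatter on either core. They also leave open what a plain hydrogen at this place would give, which would show whether either methyl or trifluoromethyl matters at all.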